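The source may hold more compounds than are shown below. What is called first, only, known or untested is meant among the compounds shown, and "the series" means these compounds.

Measured in a functional assay, with a stated time of 6 min; on this read-out higher numbers stand for weaker inhibition and lower numbers for stronger inhibition:

Compound 1, `S=c1oc(-c2ccc3c(c2)OCCO3)nn1CNc1cc(Cl)ccc1Cl`, gives 5420 nM.
Compound 2, `S=c1oc(-c2ccc3c(c2)OCCO3)nn1CNc1cccc(Br)c1`, gives 10800 nM.

Compound 2 carries the larger of the two measured numbers, with compound 1 nearest to it; the step of a 2.0-fold higher number from compound 1 to compound 2 (0.30 log units; within the scatter) lies within the scatter, so the two compounds cannot be told apart on these data.

Compound 3, `O=[N+]([O-])c1cccc(NCn2nc(-c3ccc4c(c3)OCCO4)oc2=S)c1`, is not yet measured. It differs from compound 2 by nitro in place of bromo on an aromatic carbon, on an aromatic carbon of a six-membered aromatic ring of carbon only, meta to a large group; cut one bond further out the change reads 3-bromophenyl to 3-nitrophenyl.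

Among the measured compounds shown here, only one step is known, from compound 1 to compound 2, and it swaps one halogen pattern for another on the same amine nitrogen; it did not move the number beyond the scatter. For the measured compounds named here, no measured step puts a nitro group in this place, so there is nothing that points to a shift in either direction in this assay. For compound 3 a step of a 1.2-fold lower number from compound 2 to compound 3 (0.08 log units; within the scatter) is therefore expected, which is within the scatter. Compound 3 is estimated at 9000 nM, with a range from 3000 nM to 27000 nM.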

Compound 3, half-maximal inhibitory concentration: 8870 nM
For compound 3 the middle estimate is 1.0-fold (0.01 log units) above the measured one, and the stated range covers the measured number.
By their numbers in this assay, from the lowest: compounds 1, 3 and 2 (each within the scatter of the next).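

In this assay, nitro in place of bromo on this aromatic carbon, meta to a large group, gives a 1.2-fold lower number from compound 2 to compound 3 (0.09 log units; within the scatter) and so adds something the earlier halogen-only pair could not show: a non-halogen group with 3 heavy atoms and 2 hydrogen-bond acceptors leaves the read-out indistinguishable from that of the single bromine. The wider exchange of the 2,5-dichlorophenyl for 3-nitrophenyl gives a 1.6-fold higher number from compound 1 to compound 3 (0.21 log units; within the scatter) and likewise stays within the scatter, so the three aryl groups shown on the amine nitrogen cannot be separated in this assay. No measured information on these compounds accounts for this lack of separation.

What remains open is whether any group at this place can move the number beyond the scatter in either direction, since an amine, a carboxylic acid or a methoxy group stands at this place in none of the compounds shown. On these data alone, it is also open whether the unsubstituted phenyl would read the same, and whether a nitro group on another carbon of this ring would do so.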